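Removing the Ethyl Group from Compound 2

The source may report more compounds than this note shows. Statements on the series, on what has been measured and on what is new or still open speak of the compounds shown alone.

Compound 1: `CCOC(=O)c1oc2ccc(NS(=O)(=O)c3ccc(F)cc3)cc2c1C` — in a functional assay on HCT-116 cells (Homo sapiens) for inhibition, read by MTT assay, with a stated time of 72 h (on this read-out higher numbers stand for weaker inhibition and lower numbers for stronger inhibition), compound 1 gives > 40000 nM, which is a limit of the assay and not a number.
Compound 2: `CCOC(=O)c1oc2ccc(N(Cc3ccccc3)S(=O)(=O)c3ccc(F)cc3)cc2c1C` — in this assay compound 2 gives 33100 nM.

For the measured compounds named here, compound 2 is the only compound of the two with a numerical result; the other result is a limit. The step between them, an at least 1.2-fold lower number from compound 1 to compound 2 (0.08 log units; that floor lies within the scatter), is small and lies within the scatter of the assay, so the two compounds cannot be told apart on these numbers. Compound 3, `Cc1c(C(=O)O)oc2ccc(N(Cc3ccccc3)S(=O)(=O)c3ccc(F)cc3)cc12`, has not yet been tested. It differs from compound 2 by hydrogen in place of ethyl on an oxygen next to a carbonyl group, so the ethoxycarbonyl of compound 2 becomes a carboxy group. Going by the values given here, no measured step touches this position; the only measured step concerns the sulfonamide nitrogen and lies within the scatter. There is therefore no basis for expecting a change beyond the scatter in this assay in either direction. The estimate for compound 3 is 40000 nM, with a range from 15000 nM to 120000 nM. This estimate means an expected step of a 1.2-fold higher number from compound 2 to compound 3 (0.08 log units; within the scatter), and a result reported only as a limit would not be surprising.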

Compound 3, half-maximal inhibitory concentration: > 40000 nM
Compound 3: a limit, no number (the forecaster's own chance of this, stated with the estimate: 55%); the middle value lies on the limit itself.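

With this result, the ester position has its first measured step in this assay: the change from ethoxycarbonyl to carboxy gives an at least 1.2-fold higher number from compound 2 to compound 3 (0.08 log units; that floor lies within the scatter). The result for compound 3 is a limit and not a number, so this step has a floor but no known size, and it may or may not go beyond the scatter. What can be said is that hydrogen in place of ethyl on this oxygen gives no sign of a gain in inhibition, and the step cannot be sized further because the results for this small set run into the end of the assay's range: the limit of > 40000 nM in this assay, at which 2 of the 3 values shown sit.

The compounds shown leave open how other groups would read at this place, for example a primary amide, a methyl ester or an ester with a longer chain, any of which could show whether the position tolerates change at all. They also leave open whether a carboxy group would read the same way with hydrogen rather than benzyl on the sulfonamide nitrogen.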